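A few compounds are considered here, and "the series" means these few. Any claim that something is new, unique, unknown or untested is made for them only; others in the source may bear on it.

In a functional assay on KB cells (Homo sapiens) for antiproliferative activity, read by MTT assay, with a stated time of 48 h (a higher number here means a weaker inhibitor, a lower number a stronger inhibitor), three compounds have been measured:

Compound 1 `Cn1cc(C2=C(c3nn(CCCn4cncn4)c4ncccc34)C(=O)NC2=O)c2ccccc21`: > 100000 nM, a limit
Compound 2 `Cn1cc(C2=C(c3nn(CCCn4ccnc4)c4ncccc34)C(=O)NC2=O)c2ccccc21`: > 100000 nM, a limit
Compound 3 `Cn1cc(C2=C(c3n[nH]c4ncccc34)C(=O)NC2=O)c2ccccc21`: 62000 nM

For the measured compounds named here, compound 3 holds the only actual number among the three, and it has no chain on the aromatic nitrogen. Compound 1 and compound 2 are known only through (the limit of > 100000 nM in this assay, at which 2 of the 3 values shown sit).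

The next compound, compound 4 `Cn1cc(C2=C(c3nn(CCn4ccnc4)c4ncccc34)C(=O)NC2=O)c2ccccc21`, is related to compound 3 by 2-(1H-imidazol-1-yl)ethyl in place of hydrogen on an aromatic nitrogen. In words, this is 2-(1H-imidazol-1-yl)ethyl in place of hydrogen on an aromatic nitrogen.

The closest evidence runs the other way, from chain-bearing compounds to the bare nitrogen. Compound 2, which carries 3-(1H-imidazol-1-yl)propyl, gives an at least 1.6-fold lower number from compound 2 to compound 3 (0.20 log units; that floor lies within the scatter). Compound 1, with its triazolyl chain, gives an at least 1.6-fold lower number from compound 1 to compound 3 (0.20 log units; that floor lies within the scatter). Both figures are floors, so the true steps could be larger. The change of ring between the two chains offers no guidance, as a step that the two limits leave unreadable from compound 1 to compound 2 shows. Going by the values given here, no compound with the 2-(1H-imidazol-1-yl)ethyl chain has yet been measured.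

A modest rise is therefore expected in this assay, and the assay may report only a limit. The expected change is a 1.5-fold higher number from compound 3 to compound 4 (0.16 log units; within the scatter). The estimate for compound 4 is 90000 nM, with an expected range of 35000 nM to 200000 nM.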

Compound 4, half-maximal inhibitory concentration: > 100000 nM
Compound 4: no number, only a limit; the forecaster's own chance of this, stated with the estimate: 65%; middle value at least 1.1-fold (0.04 log units) from the limit.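

In this assay, the forward change on this aromatic nitrogen can now be read directly: 2-(1H-imidazol-1-yl)ethyl in place of hydrogen gives an at least 1.6-fold higher number from compound 3 to compound 4 (0.20 log units; that floor lies within the scatter). Until now, this nitrogen had been seen carrying only propyl chains, and the ethyl chain shows that the shorter link to the imidazole ring also gives no readable number, so all three chain-bearing compounds end at the same limit: the limit of > 100000 nM in this assay, at which 3 of the 4 values shown sit. The steps from compound 1 and from compound 2 to compound 4 cannot be read, since each joins two limits, and the change from propyl to ethyl therefore has no measurable size here.

Since the only step from the bare nitrogen has a floor within the scatter, the compounds shown leave open how far any of these chains really moves the number from that of compound 3. They also leave open whether a group of another kind on this nitrogen, such as a methyl, a chain ending in an amine or one ending in a carboxylic acid, would give a number rather than a limit.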